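Azetidine in place of methyl on the amide nitrogen

The source may report more compounds than this note shows. Statements on the series, on what has been measured and on what is new or still open speak of the compounds shown alone.

Compound 3 `CNC(=O)c1cc(-c2ccc(NS(=O)(=O)c3cccc(Cl)c3Cl)cc2)nc2[nH]ncc12` gives 929 nM in an assay for inhibition of serine/threonine-protein kinase Sgk1 (Homo sapiens), with stated times of 30 min and 60 min, in the presence of a further agent that is not named here (on this read-out higher numbers stand for weaker inhibition and lower numbers for stronger inhibition), the highest number of the three measured. Compound 1 `CN1CCC(NC(=O)c2cc(-c3ccc(NS(=O)(=O)c4cccc(Cl)c4Cl)cc3)nc3[nH]ncc23)C1` gives 21 nM and compound 2 `O=C(NC1CCN(C2CC2)C1)c1cc(-c2ccc(NS(=O)(=O)c3cccc(Cl)c3Cl)cc2)nc2[nH]ncc12` gives 610 nM. Two steps lead into compound 3: a 44-fold higher number from compound 1 to compound 3 (1.65 log units; beyond the scatter), and a 1.5-fold higher number from compound 2 to compound 3 (0.18 log units; within the scatter). The first is large, the second lies within the scatter, so the amide substituent matters strongly when its basic nitrogen carries methyl and hardly at all when it carries cyclopropyl; the direct comparison a 29-fold higher number from compound 1 to compound 2 (1.46 log units; beyond the scatter) shows the same thing.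

Compound 4 `CN1CC(NC(=O)c2cc(-c3ccc(NS(=O)(=O)c4cccc(Cl)c4Cl)cc3)nc3[nH]ncc23)C1` differs from compound 3 by 1-methylazetidin-3-yl in place of methyl on an amide-type nitrogen. The entering group carries a methyl on its ring nitrogen, as in compound 1, and the change runs opposite to the step from compound 1 to compound 3. A large step downward is therefore expected, though the smaller ring may not recover the full distance: a 15-fold lower number from compound 3 to compound 4 (1.19 log units; beyond the scatter) is the expected size. Compound 4 is estimated at 60 nM, with a range from 15 nM to 250 nM.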

Compound 4, half-maximal inhibitory concentration: < 1 nM
Compound 4: a limit, no number (the forecaster's own chance of this, stated with the estimate: 2%); middle value at least 60-fold (1.77 log units) from the limit.
By their numbers in this assay, from the lowest: compound 1; then compounds 2 and 3 (each within the scatter of the next). At a limit, below all of these: compound 4.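

Compound 4 stands at a limit, not at a number: the limit of < 1 nM in this assay, at which 1 of the 4 values shown sits. Within the data shown here, with the methyl on the ring nitrogen kept, ring size on the amide-type nitrogen alone moves the value by a large step, which the earlier compounds could not show: an at least 21-fold lower number from compound 1 to compound 4 (1.32 log units; beyond the scatter). The azetidine also sets compound 4 far from the other two compounds, with an at least 920-fold lower number from compound 3 to compound 4 (2.96 log units; beyond the scatter) and an at least 610-fold lower number from compound 2 to compound 4 (2.78 log units; beyond the scatter), and all three steps are bounds, not exact sizes.

As far as these compounds go, whether the azetidine gain survives a different group on the ring nitrogen stays open, and 1-cyclopropylazetidin-3-yl would test this against the cyclopropyl result for the pyrrolidine in compound 2. From the compounds shown here alone, how the trend continues with ring size also stays open, and 1-methylpiperidin-4-yl on the same amide-type nitrogen would extend it.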